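Swapping isopropyl for phenyl on a shared core

This account rests on a few compounds, and the source may have more. Where it says the series, first, only, none or still open, it means among the compounds named here.

Compound 1, `CCCCCNc1nc(SC)nc2ncccc12`, gives 650 nM in a functional assay (Nicotiana tabacum); a lower number here means a stronger inhibitor, a higher number a weaker inhibitor.
Compound 2, `CCCCCCNc1nc(SC)nc2ncccc12`, gives 3330 nM in this assay.
Compound 3, `CSc1nc(NCC(C)C)c2cccnc2n1`, gives 540 nM in this assay.

Compound 3 has the lowest of the three numbers, though its gap to compound 1, a 1.2-fold lower number from compound 1 to compound 3 (0.08 log units; within the scatter), lies within the scatter, so the two cannot be ordered. Compound 2 stands apart: a 6.2-fold lower number from compound 2 to compound 3 (0.79 log units; beyond the scatter). Within the chain series, adding one carbon gave a 5.1-fold higher number from compound 1 to compound 2 (0.71 log units; beyond the scatter).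

Compound 4, `CSc1nc(NCc2ccccc2)c2cccnc2n1`, differs from compound 3 by phenyl in place of isopropyl on a saturated chain carbon bound to a nitrogen on an aromatic ring. The measured steps only compare saturated chains of different length; none of them introduces a ring, so they bear on the new change only loosely. They show that a small branched group and a four-carbon chain behave alike, while a six-heavy-atom chain weakens inhibition. Phenyl, also six heavy atoms but held in a ring, could sit anywhere between these outcomes.

The expected step is a 1.9-fold higher number from compound 3 to compound 4 (0.27 log units; within the scatter). Compound 4 is therefore estimated at 1000 nM, within a range of 300 nM to 4000 nM.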

Compound 4, half-maximal inhibitory concentration: 25200 nM
For compound 4 the middle estimate is 25-fold (1.40 log units) below the measured one; the whole stated range lies below it.
By their numbers in this assay, from the lowest: compounds 3 and 1 (each within the scatter of the next); then compound 2; then compound 4.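

On a saturated chain carbon bound to a nitrogen on an aromatic ring, phenyl in place of isopropyl gives a 47-fold higher number from compound 3 to compound 4 (1.67 log units; beyond the scatter) and phenyl in place of butyl gives a 39-fold higher number from compound 1 to compound 4 (1.59 log units; beyond the scatter) in this assay so a ring here is far from interchangeable with these small chains. Even against pentyl, the chain that had already weakened inhibition, phenyl gives a 7.6-fold higher number from compound 2 to compound 4 (0.88 log units; beyond the scatter) and this makes compound 4 the weakest inhibitor of the four, which the lengthening of the chain alone had not foreshadowed. No measurement available here accounts for the size of this loss.

The compounds shown leave open whether cyclohexyl, a saturated ring of carbon, would behave like phenyl or like the chains. They also leave open whether a phenyl carrying a hydroxyl or an amine would recover any inhibition.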